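Shortening the alkyne at the five-position of the shared core

The source may report more compounds than this note shows. Statements on the series, on what has been measured and on what is new or still open speak of the compounds shown alone.

Measured in an ADME assay on L1210/0 cells (Mus musculus) for cytotoxicity, with a stated time of 48 h; a higher number here means a weaker inhibitor, a lower number a stronger inhibitor:
Compound 1, `N#CSc1cn([C@H]2C[C@H](O)[C@@H](CO)O2)c(=O)[nH]c1=O`: 78900 nM
Compound 2, `C=Cc1cn([C@H]2C[C@H](O)[C@@H](CO)O2)c(=O)[nH]c1=O`: 14200 nM
Compound 3, `CCCC#Cc1cn([C@H]2C[C@H](O)[C@@H](CO)O2)c(=O)[nH]c1=O`: > 200000 nM

Compound 3 stands at the weak end of the three: its value in this assay is a limit of the assay, not a number (the limit of > 200000 nM in this assay, at which 1 of the 3 values shown sits). The steps that reach it are an at least 14-fold higher number from compound 2 to compound 3 (1.14 log units; beyond the scatter) and an at least 2.5-fold higher number from compound 1 to compound 3 (0.40 log units; beyond the scatter), both beyond the scatter, so the pent-1-yn-1-yl group leaves compound 3 weaker than either smaller substituent.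

Compound 4, `C#COc1cn([C@H]2C[C@H](O)[C@@H](CO)O2)c(=O)[nH]c1=O`, differs from compound 3 in one place: ethynyloxy in place of pent-1-yn-1-yl on an aromatic carbon. The change brings the substituent back to a size nearer that of compound 1 and compound 2, so a step in the stronger direction is expected, though a limit remains possible. Compound 4 is expected to give 80000 nM in this assay, within 15000 nM to 400000 nM. The expected step is an at least 2.5-fold lower number from compound 3 to compound 4 (0.39 log units; beyond the scatter).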

Compound 4, half-maximal inhibitory concentration: > 200000 nM
Compound 4 ended at the assay's limit (the forecaster's own chance of this, stated with the estimate: 35%); middle value at least 2.5-fold (0.39 log units) from the limit.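

In this assay compound 4 gives a limit of the assay and not a number, and the step from compound 3 cannot be read: the limit of > 200000 nM in this assay, at which 2 of the 4 values shown sit.

Cutting the group to ethynyloxy, with 3 heavy atoms against 5, still leaves an at least 14-fold higher number from compound 2 to compound 4 (1.14 log units; beyond the scatter) and an at least 2.5-fold higher number from compound 1 to compound 4 (0.40 log units; beyond the scatter) on the weak side, so a shorter group alone does not restore a measurable value here. Both alkyne-bearing compounds now sit at the limit, while compound 1 and compound 2 give numbers.

The compounds shown leave open whether the triple bond or the chain matters more at this position. An ethyl chain or an amine here would help to separate the two.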